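Dropping one chloro from the anilino ring of a weak cytotoxic chalcone

A few compounds are considered here, and "the series" means these few. Any claim that something is new, unique, unknown or untested is made for them only; others in the source may bear on it.

Compound 1 `COc1cccc(/C=C/C(=O)c2sc(Nc3ccc(Cl)c(Cl)c3)nc2C)c1`: in a functional assay on NCI-H460 cells (Homo sapiens) for cytotoxicity, read by MTT assay (on this read-out higher numbers stand for weaker inhibition and lower numbers for stronger inhibition), compound 1 gives 20100 nM.
Compound 2 `Cc1cccc(Nc2nc(C)c(C(=O)/C=C/c3ccc(Cl)cc3)s2)c1`: compound 2 reaches only the limit of this assay, > 25000 nM.
Compound 3 `COc1ccc(/C=C/C(=O)c2sc(Nc3ccc(Cl)c(Cl)c3)nc2C)cc1`: compound 3 likewise reaches only the limit, > 25000 nM.

Within the data shown here, compound 1 stands as the only compound of the three with a number rather than a limit in this assay; the two others sit at the limit of > 25000 nM in this assay, at which 2 of the 3 values shown sit. Among the measured compounds shown here, the one step with a single difference, an at least 1.2-fold higher number from compound 1 to compound 3 (0.09 log units; that floor lies within the scatter), lies within the scatter, and the difference it carries, 4-methoxyphenyl in place of 3-methoxyphenyl, is not the one asked about here. Compound 2 differs from compound 1 in more than one place, so its limit shows only that it too is weak.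

Compound 4 `COc1cccc(/C=C/C(=O)c2sc(Nc3cccc(Cl)c3)nc2C)c1` differs from compound 1 as follows: hydrogen in place of chloro on an aromatic carbon, that is, 3,4-dichlorophenyl to 3-chlorophenyl on the amino side of the shared core. For the measured compounds named here, no measured step touches this position. With all three measured compounds weak or at the limit, compound 4 is expected to remain in the same weak range, so the estimated step of a 1.2-fold higher number from compound 1 to compound 4 (0.09 log units; within the scatter) is none beyond the scatter. Compound 4 is therefore estimated at 25000 nM, between 10000 nM and 60000 nM, with a real chance that this assay again reports only a limit.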

Compound 4, half-maximal inhibitory concentration: > 25000 nM
Compound 4: only a limit was reported (the forecaster's own chance of this, stated with the estimate: 55%); the middle value lies on the limit itself.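

In this assay compound 4 reports only a limit, > 25000 nM. Among these compounds, the step of an at least 1.2-fold higher number from compound 1 to compound 4 (0.09 log units; that floor lies within the scatter) is the first reading at this position; its floor lies within the scatter, and its true size cannot be read from a limit, but it shows that going from 3,4-dichlorophenyl to 3-chlorophenyl brings no stronger inhibition. Compound 1 thus remains the only compound here with a number in this assay, and the rest sit at the limit: the limit of > 25000 nM in this assay, at which 3 of the 4 values shown sit.

From the compounds shown here alone, whether a bromo or a trifluoromethyl group in place of this chloro would give a number lower than that of compound 1 stays open. So does the part played by the chloro that remains in compound 4, and whether an amine on this ring would bring a value off the limit.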